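A few compounds are considered here, and "the series" means these few. Any claim that something is new, unique, unknown or untested is made for them only; others in the source may bear on it.

Measured compounds:
- compound 1, `CCn1cnc2c(NC(=N)N)nc(N)nc21`: 54300 nM
- compound 2, `CCn1cnc2c(N)nc(N)nc21`: > 100000 nM (a limit, not a number)
- compound 3, `CC(C)n1cnc2c(NC(=N)N)nc(NCCO)nc21`: 12400 nM

In a functional assay on MCF7 cells (Homo sapiens) for inhibition, read by fluorescence, with a stated time of 72 h (on this read-out lower numbers stand for stronger inhibition and higher numbers for weaker inhibition), compound 1 gives 54300 nM. For compound 2 the result is only a limit of the assay, > 100000 nM, so no number is known for it. Compound 3 gives 12400 nM, the lowest of the two numbers shown; compound 1 is the nearest, and the gap to it lies beyond the usual scatter.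

Compound 4, `CC(C)n1cnc2c(NC(=N)N)nc(OC[C@H]3CCCN3)nc21`, is not yet measured. It differs from compound 3 in one place: (pyrrolidin-2-yl)methoxy in place of (2-hydroxyethyl)amino on an aromatic carbon.

For the measured compounds named here, the only measured step, an at least 1.8-fold higher number from compound 1 to compound 2 (0.26 log units; that floor lies within the scatter), concerns a different position, so it does not bear on the change from compound 3 to compound 4. Going by the values given here, no measured step speaks to an exchange at this aromatic carbon. The expectation is therefore a step of modest size, if any: compound 4 is estimated at 8000 nM, with a range from 2000 nM to 30000 nM. This estimate corresponds to a 1.6-fold lower number from compound 3 to compound 4 (0.19 log units; within the scatter).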

Compound 4, half-maximal inhibitory concentration: > 100000 nM
Compound 4 ended at the assay's limit; the forecaster's own chance of this, stated with the estimate: 5%; middle value at least 12-fold (1.09 log units) away from the limit.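

In this assay, placing (pyrrolidin-2-yl)methoxy in place of (2-hydroxyethyl)amino on the aromatic carbon between two ring nitrogen atoms gives an at least 8.0-fold higher number from compound 3 to compound 4 (0.90 log units; beyond the scatter), so the read-out at this position clearly depends on which group sits there. Compound 4 gives > 100000 nM, which is a limit of the assay and not a number. Only a floor for the step can be stated, because the readings stop at this limit: the limit of > 100000 nM in this assay, at which 2 of the 4 values shown sit.

The change swaps an amino link for an oxygen link and an open chain for a five-membered ring at once, and the compounds shown do not separate these two parts. Going by these compounds, a 2-hydroxyethoxy group or a (pyrrolidin-2-yl)methylamino group at this carbon would pull them apart, and how either would read remains open.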